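Bromo to methoxy in an antiproliferative pair

A few compounds are considered here, and "the series" means these few. Any claim that something is new, unique, unknown or untested is made for them only; others in the source may bear on it.

Within the data shown here, in a functional assay (Homo sapiens) for antiproliferative activity, read by sulforhodamine B assay, with a stated time of 48 h (on this read-out higher numbers stand for weaker inhibition and lower numbers for stronger inhibition), compound 2 (`O=C1NCCN1c1ccc(S(=O)(=O)Nc2cccc(Br)c2)cc1`) gives 270 nM as the lower of the two numbers so far. Compound 1 (`O=C1NCCN1c1ccc(S(=O)(=O)Nc2ccc3[nH]ccc3c2)cc1`) gives 770 nM in the same test, a higher number by a gap beyond the usual scatter. Compound 3 (`COc1cccc(NS(=O)(=O)c2ccc(N3CCNC3=O)cc2)c1`) has yet to be measured. It carries methoxy in place of bromo on an aromatic carbon, meta to a large group, and the change is methoxy in place of bromo on an aromatic carbon in full. Among the measured compounds shown here, no measured pair shows this exchange, so the expectation is cautious: a small move toward a higher number in this assay that stays within the scatter, with compound 2 at 270 nM as the reference. The expected change is a 1.7-fold higher number from compound 2 to compound 3 (0.22 log units; within the scatter) on this estimate. Compound 3 is estimated at 450 nM with a range from 150 nM to 1400 nM expected for it.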

Compound 3, half-maximal inhibitory concentration: 370 nM
The estimate for compound 3 lay 1.2-fold (0.09 log units) above the measured number; the measured number falls inside the stated range.
By their numbers in this assay, from the lowest: compounds 2 and 3 (each within the scatter of the next); then compound 1.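

In this assay the exchange of bromo for methoxy on an aromatic carbon, meta to a large group, gives a 1.4-fold higher number from compound 2 to compound 3 (0.14 log units; within the scatter) and so leaves the 3-bromophenyl and 3-methoxyphenyl compounds indistinguishable on this read-out. Among these compounds, this pair is the first direct view of the position, and it shows that, on the shared core, bromo can give way to methoxy, which brings a hydrogen-bond acceptor, without a step beyond the scatter. Nothing available accounts for the two groups reading alike. The compounds shown leave open what an amine, a carboxylic acid or a longer alkoxy chain would do at this carbon, and how the ring would read with hydrogen there. They also leave open whether this exchange reads the same way on another core, as it rests on a single pair.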